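Pyrimidin-5-yl for pyridin-2-yl on the thioether chain

The source may hold more compounds than are shown below. What is called first, only, known or untested is meant among the compounds shown, and "the series" means these compounds.

Measured compounds, with their values in an assay on isolated protein for inhibition of Retinaldehyde dehydrogenase 3 (Homo sapiens); on this read-out higher numbers stand for weaker inhibition and lower numbers for stronger inhibition:
compound 1, `CC(Sc1nc2nn(CC3COC3)cc2c(=O)n1-c1ccccc1)c1ccccc1`, gives 60 nM
compound 2, `CC(Sc1nc2c(cnn2C)c(=O)n1-c1ccccc1)c1ccccn1`, gives 89 nM
compound 3, `CC(Sc1nc2c(cnn2C)c(=O)n1-c1ccc(C#N)cc1)c1ccccc1`, gives 200 nM

Compound 2 stands second highest of the three numbers in this assay. Its nearest neighbour is compound 1, whose number is lower by an amount that lies within the scatter, so the two cannot be told apart. Compound 3 sits furthest away, with a higher number that lies beyond the scatter.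

Compound 4, `CC(Sc1nc2c(cnn2C)c(=O)n1-c1ccccc1)c1cncnc1`, has not been measured in this assay. It differs from compound 2 in one place: pyrimidin-5-yl in place of pyridin-2-yl on a saturated chain carbon bound to a saturated chain carbon and a sulfur. Going by the values given here, no pair among the measured compounds shows this exchange, so the size of the step has no direct precedent here. Compound 1 and compound 3 carry a plain phenyl at that chain carbon and, with their other differences, frame compound 2 on both sides, which suggests that the group on this chain carbon has not moved the number far within these three compounds.

The step from compound 2 to compound 4 is therefore expected to be small, a 1.3-fold higher number from compound 2 to compound 4 (0.13 log units; within the scatter), with no direction that can be called beyond the scatter. Compound 4 is estimated to give 120 nM in this assay, within a range from 40 nM to 400 nM.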

Compound 4, half-maximal inhibitory concentration: 100 nM
Beside the measured number, compound 4's estimate is 1.2-fold (0.08 log units) above it; measured number inside the range.
By their numbers in this assay, from the lowest: compounds 1, 2, 4 and 3 (each within the scatter of the next, the first and the last beyond it).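

In this assay, the exchange on the saturated chain carbon bound to a saturated chain carbon and a sulfur now has a direct reading: a 1.1-fold higher number from compound 2 to compound 4 (0.05 log units; within the scatter). Pyridin-2-yl has 1 hetero atom and 1 hydrogen-bond acceptor and pyrimidin-5-yl has 2 of each, yet with the same 6 heavy atoms and the rest of the molecule unchanged, compound 2 and compound 4 cannot be told apart, so this single pair shows no response to the exchange. No evidence is at hand that would explain this outcome.

The compounds shown leave open whether the same holds for a plain phenyl at this chain carbon on the otherwise unchanged structure of compound 2, since compound 1 and compound 3 each differ from it in more than one place. They also leave open how the number would respond to a group of a different kind at this chain carbon, such as a carboxylic acid, an amine or a longer chain, since both rings compared here are six-membered and aromatic.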